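A few compounds are considered here, and "the series" means these few. Any claim that something is new, unique, unknown or untested is made for them only; others in the source may bear on it.

Measured compounds:
compound 1 `Cc1cc(O)c(C(=O)/C=C/c2ccccc2)c(-c2ccccc2)c1C(=O)/C=C/c1ccccc1` — 10000 nM
compound 2 `Cc1cc(O)c(C(=O)/C=C/c2ccc(OCc3ccccc3)cc2)c(-c2ccccc2)c1C(=O)/C=C/c1ccc(OCc2ccccc2)cc1` — 10000 nM

In a functional assay on MCF7 cells (Homo sapiens) for cytotoxicity, read by MTT assay, with a stated time of 24 h (a lower number here means a stronger inhibitor, a higher number a weaker inhibitor), compound 1 gives 10000 nM. Compound 2, in this assay, gives 10000 nM; the two values stand level at the digits shown, and the difference between them lies within the scatter of repeated runs, so no order between compound 1 and compound 2 can be read from them.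

Compound 3 `Cc1cc(O)c(C(=O)/C=C/c2ccc(OCc3ccccc3)cc2)c(-c2ccc(OCc3ccccc3)cc2)c1C(=O)/C=C/c1ccc(OCc2ccccc2)cc1` is the next member. Relative to compound 2 the change is benzyloxy in place of hydrogen on an aromatic carbon. Within the data shown here, no measured step between any two compounds in the set is available, so the size of this step is not known from data. Since compound 1 and compound 2 give the same reading in this assay, the expectation for compound 3 is a step of no change at the digits printed from compound 2 to compound 3 (within the scatter), that is none beyond the scatter, in no preferred direction. Compound 3 is therefore estimated at 10000 nM in this assay, with a range from 5000 nM to 20000 nM.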

Compound 3, half-maximal inhibitory concentration: 26000 nM
Beside the measured number, compound 3's estimate is 2.6-fold (0.41 log units) below it; measured number outside the range, above it.
By their numbers in this assay, from the lowest: compounds 1 and 2 (each within the scatter of the next); then compound 3.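

In this assay, among these compounds, benzyloxy in place of hydrogen on an aromatic carbon, para to a large group, gives a 2.6-fold higher number from compound 2 to compound 3 (0.41 log units; beyond the scatter), the only step so far that can be read. This position is therefore not indifferent to substitution: on the background of compound 2, the added benzyloxy group moves the number modestly towards weaker inhibition. No measurement on hand accounts for this step, which stands as an observation on a single pair.

Still open, as far as these compounds go, is whether a methoxy group, a fluorine atom, an amine or a carboxylic acid at this position would shift the number in the same direction. Also open, from the compounds shown here alone, is whether benzyloxy here has the same effect on the core of compound 1, without the other two benzyloxy groups.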